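This account rests on a few compounds, and the source may have more. Where it says the series, first, only, none or still open, it means among the compounds named here.

Working notes on the series. The shared core is a benzyl amide carrying an octyl chain; the amino-acid portion on the carbonyl is what varies. Compound 1 `CCCCCCCCc1ccc(NC(=O)[C@H](N)[C@H](C)O)cc1` gives 2100 nM in an assay on isolated protein for inhibition of sphingosine kinase 1 (Homo sapiens), read by mobility shift assay; on this read-out higher numbers stand for weaker inhibition and lower numbers for stronger inhibition. Compound 2 `CCCCCCCCc1ccc(CNC(=O)C(N)CO)cc1` differs from compound 1 in the benzyl linker and in the amino-acid portion. In this assay compound 2 gives > 10000 nM, which is a limit of the assay and not a number. That reading sits at the limit of > 10000 nM in this assay, at which 1 of the 2 values shown sits, so no actual value for compound 2 is known; only that it is weaker than the limit allows to resolve.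

Compound 3 `CCCCCCCCc1ccc(CNC(=O)[C@H]2NCC[C@@H]2O)cc1` is not yet measured. The change from compound 2 to compound 3 is 3-hydroxypyrrolidin-2-yl in place of 1-amino-2-hydroxyethyl on a carbonyl carbon. Within the data shown here, as no measured step between two compounds exists here, no size of step can be read off, and the change in this assay is expected to be modest in either direction, with a small gain the more likely outcome, as the step of an at least 1.2-fold lower number from compound 2 to compound 3 (0.09 log units; that floor lies within the scatter) is estimated to show. Compound 3 is expected to give about 8000 nM in this assay, within a range from 2000 nM to 30000 nM.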

Compound 3, half-maximal inhibitory concentration: 430 nM
Estimate against measurement, compound 3: 19-fold (1.27 log units) above; the measured number lies below the stated range.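

In this assay, among these compounds, 3-hydroxypyrrolidin-2-yl in place of 1-amino-2-hydroxyethyl on a carbonyl carbon gives an at least 23-fold lower number from compound 2 to compound 3 (1.36 log units; beyond the scatter), the first readable step at this position, and it shows that the amino-alcohol portion on the benzyl amide can strongly change the read-out with the octyl chain and the rest of the shared core unchanged. The hydrogen-bond donor and acceptor counts stay the same across this change, while the entering group brings a five-membered non-aromatic ring and 2 defined stereocentres, so the step comes with no change in those counts. Compound 2 gives > 10000 nM, which is a limit of the assay and not a number, so the full size of the step stays unresolved: the limit of > 10000 nM in this assay, at which 1 of the 3 values shown sits.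

The compounds shown leave open whether the ring, the hydroxyl or the defined stereocentres carry the step, as they cannot separate these features from one another. Open comparisons on the same core would be pyrrolidin-2-yl without the hydroxyl, a methoxy group in place of that hydroxyl, and the other stereoisomers of 3-hydroxypyrrolidin-2-yl.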